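Phenylsulfanyl in place of phenoxymethyl: notes toward compound 4

A few compounds are considered here, and "the series" means these few. Any claim that something is new, unique, unknown or untested is made for them only; others in the source may bear on it.

Measured so far:
compound 1, `COc1cc(OCc2cccc(COc3ccccc3)c2)c2cc(-c3cn4nc(OC)sc4n3)oc2c1` — 3.2 nM
compound 3, `Cc1nn2cc(-c3cc4ccccc4o3)nc2s1` — 37 nM
compound 2, `c1ccc(Sc2nn3cc(-c4cc5ccccc5o4)nc3s2)cc1` — 1900 nM

All three were run in a functional assay on HEK293 cells for antagonist activity at proteinase-activated receptor 4 (Homo sapiens), read by FLIPR and calcium flux, with a stated time of 30 min; a higher number here means a weaker inhibitor, a lower number a stronger inhibitor. Compound 1 stands lowest of the three numbers; compound 3 is nearest, and compound 2 furthest, both gaps beyond the scatter.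

Within the data shown here, only one step between measured compounds differs in a single place: a 51-fold lower number from compound 2 to compound 3 (1.71 log units; beyond the scatter). That change sits on the shared core, not on the ether side chain, so it speaks to the phenylsulfanyl group only indirectly, and in the opposite sense (removal rather than introduction).

Compound 4 is `COc1cc(OCc2cccc(Sc3ccccc3)c2)c2cc(-c3cn4nc(OC)sc4n3)oc2c1`. It differs from compound 1 by phenylsulfanyl in place of phenoxymethyl on an aromatic carbon. Among the measured compounds shown here, nothing measured carries a phenylsulfanyl on the side-chain ring, so no directly matching step exists. The group that leaves and the group that enters are both aromatic with one hydrogen-bond acceptor, and the side-chain ring is retained. The step of a 1.9-fold higher number from compound 1 to compound 4 (0.27 log units; within the scatter) is therefore expected to be small, if anything a somewhat higher number, with wide uncertainty given the lack of a comparable measured step. Compound 4 is expected to give 6 nM, with a range of 1.5 nM to 25 nM.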

Compound 4, half-maximal inhibitory concentration: 0.89 nM
Estimate against measurement, compound 4: 6.7-fold (0.83 log units) above; measured number outside the range, below it.
By their numbers in this assay, from the lowest: compound 4; then compound 1; then compound 3; then compound 2.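

In this assay, the aromatic carbon meta to a large group on the side-chain ring accepts a change of linker and responds to it: a 3.6-fold lower number from compound 1 to compound 4 (0.56 log units; beyond the scatter) shows that phenoxymethyl is not the best-performing group tested at this position, and that the gain comes with the smaller phenylsulfanyl group, at 7 heavy atoms against 8. Among these compounds, the only earlier step involving phenylsulfanyl, a 51-fold lower number from compound 2 to compound 3 (1.71 log units; beyond the scatter) on an aromatic carbon of the core, ran the other way, with the lower number following its replacement by methyl, so across these two steps phenylsulfanyl is not tied to one direction of change. The data at hand give no reason for the new step.

The compounds shown do not separate the contribution of the sulfur from that of the shorter link, which phenoxy or benzylsulfanyl at the same carbon would address, and phenylsulfonyl would extend the comparison to an oxidised linker. They also leave open whether this position tolerates a group without an aromatic ring, such as an amine or a carboxylic acid, and whether the step holds on a core bearing methyl in place of methoxy.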